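Trimethoxyphenyl pyrazole chalcones: aryl ketone replacement

This account rests on a few compounds, and the source may have more. Where it says the series, first, only, none or still open, it means among the compounds named here.

Measured so far:
compound 1 `COc1cc(-c2cc(/C=C/C(=O)c3ccc(N)cc3)[nH]n2)cc(OC)c1OC`, 1620 nM
compound 2 `COc1ccc(C(=O)/C=C/c2cc(-c3cc(OC)c(OC)c(OC)c3)n[nH]2)cc1OC`, 180 nM

In a functional assay on NCI-H522 cells (Homo sapiens) for inhibition, read by sulforhodamine B assay, with a stated time of 48 h (a higher number here means a weaker inhibitor of growth, a lower number a stronger inhibitor of growth), compound 2 holds the lowest of the two numbers; its nearest neighbour is compound 1, which gives 1620 nM. Compound 3 `COc1cc(-c2cc(/C=C/C(=O)c3ccc(F)c(F)c3)[nH]n2)cc(OC)c1OC` is not yet measured. It differs from compound 2 by 3,4-difluorophenyl in place of 3,4-dimethoxyphenyl on a carbonyl carbon. For the measured compounds named here, the one step at this position, a 9.0-fold lower number from compound 1 to compound 2 (0.95 log units; beyond the scatter), shows the ketone aryl group matters, but neither measured compound carries a halogenated ring, so direction is uncertain. A modest rise is expected, a 2.8-fold higher number from compound 2 to compound 3 (0.44 log units; beyond the scatter), giving compound 3 an estimated 500 nM, within 150 nM to 2000 nM.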

Compound 3, concentration for 50% growth inhibition: 1570 nM
For compound 3 the middle estimate is 3.1-fold (0.50 log units) below the measured one, and the stated range covers the measured number.
By their numbers in this assay, from the lowest: compound 2; then compounds 3 and 1 (each within the scatter of the next).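

In this assay the change to 3,4-difluorophenyl gives up the gain seen with 3,4-dimethoxyphenyl, with an 8.7-fold higher number from compound 2 to compound 3 (0.94 log units; beyond the scatter). Against the amine-bearing ring there is a 1.0-fold lower number from compound 1 to compound 3 (0.01 log units; within the scatter), so among these three compounds only 3,4-dimethoxyphenyl on the carbonyl carbon stands apart, while 3,4-difluorophenyl and 4-aminophenyl cannot be told apart. Nothing available explains this difference.

As far as these compounds go, whether a single methoxy group on the ring would keep the lower number remains open. So does the effect of replacing the fluorines with chlorine or hydroxyl groups.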